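The source may report more compounds than this note shows. Statements on the series, on what has been measured and on what is new or still open speak of the compounds shown alone.

Measured in a functional assay on HO8910 cells (Homo sapiens) for inhibition, read by MTT assay, with a stated time of 24 h, tested at 100 ug/mL; a higher number here means more inhibition of growth at the concentration tested, a lower number less inhibition of growth:

- Compound 1 `O=C(CCCCC(S)CCS)NO`: 49.3%
- Compound 2 `O=C(CCCCC(S)CCS)Nc1ccccc1`: 13.7%
- Compound 3 `O=C(CCCCC(S)CCS)Nc1cccc(C(F)(F)F)c1`: 34.8%

Of these three compounds, compound 2 stands lowest, with 13.7%, and compound 3 is its nearest neighbour. Compound 4 `O=C(CCCCC(S)CCS)Nc1ccc(OC(F)(F)F)cc1` has not yet been measured. It departs from compound 2 by one change: trifluoromethoxy in place of hydrogen on an aromatic carbon. In other words, trifluoromethoxy takes the place of hydrogen on an aromatic carbon, para to a large group.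

Two measured steps offer context. The step of a number 35.6 percentage points lower from compound 1 to compound 2 (beyond the scatter) arose from phenyl in place of hydroxy on an amide-type nitrogen, so it says little about a change on the aromatic ring. The closer precedent is compound 3, where trifluoromethyl in place of hydrogen on an aromatic carbon gave a number 21.1 percentage points higher from compound 2 to compound 3 (beyond the scatter). That single precedent involves a different group, so a rise of similar or slightly smaller size in this assay is expected, with wide uncertainty. The expected step is a number 18.3 percentage points higher from compound 2 to compound 4 (beyond the scatter). For compound 4, the estimated value is 32%, with an expected range of 17% to 48%.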

Compound 4, percent growth inhibition at one concentration: 66.8%
For compound 4 the middle estimate is 34.8 percentage points below the measured one; the measured number lies above the stated range.
By their numbers in this assay, from the lowest: compound 2; then compound 3; then compound 1; then compound 4.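

In this assay, trifluoromethoxy on an aromatic carbon, para to a large group, gave a number 53.1 percentage points higher from compound 2 to compound 4 (beyond the scatter) and so showed that a single substituent at this position on the ring of compound 2 can produce a large change. Within the data shown here, the only earlier ring change, a different group, gave a number 21.1 percentage points higher from compound 2 to compound 3 (beyond the scatter) and was modest in size, so the earlier compounds did not show that a ring substituent could move the number this far. Nothing available here accounts for the size of this step.

On these data alone, what methoxy or a single chlorine atom would do on the same aromatic carbon remains open, and so does the effect of trifluoromethoxy on another carbon of the ring. Whether this step would hold at other concentrations is also unanswered.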